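Clearance outlook for compound 3

A few compounds are considered here, and "the series" means these few. Any claim that something is new, unique, unknown or untested is made for them only; others in the source may bear on it.

In an ADME assay on microsomes from liver (Rattus norvegicus) for metabolic stability (a higher number here means faster removal of the compound, a lower number slower removal), compound 1 (`Cc1cc(C)c2cc(C(=O)NC3CN(c4cc(Cl)ncc4Cl)C3)ccc2n1`) gives 295 mL/min/kg and compound 2 (`Cc1cc(C)c2cc(C(=O)NC3CN(c4ccnc(F)c4F)C3)ccc2n1`) gives 232 mL/min/kg so the two stand within the scatter of each other. Among the compounds with values here, these are the only numbers so far, and neither compound separates from the other.

The next change leads to compound 3 (`COc1cc(N2CC(NC(=O)c3ccc4nc(C)cc(C)c4c3)C2)c(Cl)cn1`) and is 5-chloro-2-methoxypyridin-4-yl in place of 2,3-difluoropyridin-4-yl on an amine nitrogen in a ring with the rest of the structure kept. In words, 5-chloro-2-methoxypyridin-4-yl replaces 2,3-difluoropyridin-4-yl on an amine nitrogen in a ring.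

Within the data shown here, one measured step bears on this place: a 1.3-fold lower number from compound 1 to compound 2 (0.10 log units; within the scatter) and it stays within the scatter. Among the measured compounds shown here, no measured compound carries a methoxy group, so the data do not test that feature, and one small step is thin evidence. No shift beyond the scatter is therefore expected in this assay and no direction is favoured. The expected step is a 1.1-fold higher number from compound 2 to compound 3 (0.03 log units; within the scatter) and it remains within the scatter. The estimate for compound 3 is 250 mL/min/kg with an expected range (140 mL/min/kg to 400 mL/min/kg) that stays wide.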

Compound 3, clearance: 178 mL/min/kg
Beside the measured number, compound 3's estimate is 1.4-fold (0.15 log units) above it, within the range that was stated.
By their numbers in this assay, from the lowest: compounds 3, 2 and 1 (each within the scatter of the next).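

In this assay, the methoxy group now enters the data, and 5-chloro-2-methoxypyridin-4-yl in place of 2,3-difluoropyridin-4-yl on an amine nitrogen in a ring gives a 1.3-fold lower number from compound 2 to compound 3 (0.12 log units; within the scatter). The cleaner single-place reading is methoxy in place of chloro on an aromatic carbon, which gives a 1.7-fold lower number from compound 1 to compound 3 (0.22 log units; within the scatter), so this exchange also stays inside the scatter and the position has so far tolerated chloro, fluoro and methoxy substitution on the pyridine without any pair separating in this read-out. Nothing available explains why the three numbers fall where they do.

The compounds shown leave open whether a group of another kind on this pyridine, such as a carboxylic acid, a primary amine or a longer chain like ethoxy, would move the number beyond the scatter. On these data alone, they also vary only the group on the amine nitrogen of the four-membered ring, so the contribution of the amide and the shared core to clearance remains open.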